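Methyl on the benzoyl ring of the shared core: cytotoxicity

The source may report more compounds than this note shows. Statements on the series, on what has been measured and on what is new or still open speak of the compounds shown alone.

In an ADME assay on HEK-293T cells (Homo sapiens) for cytotoxicity, read by MTT assay, with a stated time of 24 h (on this read-out lower numbers stand for higher toxicity in this test and higher numbers for lower toxicity in this test), compound 3 `Cc1ccc(-c2nn(-c3ccccc3)cc2-c2nc3ccccc3n2C(=O)c2ccccc2)cc1` gives 204000 nM, compound 1 `Cc1ccc(-c2nn(-c3ccccc3)cc2-c2nc3ccccc3n2C(=O)c2ccccc2C)cc1` gives 176000 nM and compound 2 `Cc1cccc(C(=O)n2c(-c3cn(-c4ccccc4)nc3-c3ccc(C(F)(F)F)cc3)nc3ccccc32)c1` gives 154000 nM; all three lie within the scatter of one another, so no order among them can be read. Compound 4 `Cc1ccc(-c2nn(-c3ccccc3)cc2-c2nc3ccccc3n2C(=O)c2cccc(C)c2)cc1` differs from compound 3 by methyl in place of hydrogen on an aromatic carbon. For the measured compounds named here, the one measured step of the same kind, a 1.2-fold higher number from compound 1 to compound 3 (0.06 log units; within the scatter), removed a methyl from the benzoyl ring and stayed within the scatter. A methyl entering that ring is therefore expected to give no step beyond the scatter in this assay. Compound 4 is estimated at 195000 nM, between 120000 nM and 310000 nM, an expected step of a 1.0-fold lower number from compound 3 to compound 4 (0.02 log units; within the scatter).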

Compound 4, half-maximal cytotoxic concentration: 195000 nM
The estimate for compound 4 equals the measured number at the digits printed; the range from low to high includes it.
By their numbers in this assay, from the lowest: compounds 2, 1, 4 and 3 (each within the scatter of the next).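

In this assay a methyl at this place on the benzoyl ring, meta to a large group, reads the same as hydrogen: a 1.0-fold lower number from compound 3 to compound 4 (0.02 log units; within the scatter). The place of the methyl on that ring also leaves the number unresolved, with 3-methylphenyl in place of 2-methylphenyl giving a 1.1-fold higher number from compound 1 to compound 4 (0.04 log units; within the scatter). Methyl in place of trifluoromethyl on an aromatic carbon, a change away from the benzoyl ring, gives a 1.3-fold higher number from compound 2 to compound 4 (0.10 log units; within the scatter).

Going by these compounds, whether an amine or a carboxylic acid on the benzoyl ring would give a step beyond the scatter remains open. Nothing available offers an explanation for these readings.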